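The compounds below may be only part of what the source reports. "The series", "measured", "known", "first", "only" and "open" are said of these compounds alone.

Measured so far in a functional assay on cells (Cancer cell lines, Homo sapiens) for cytotoxicity; a higher number here means that more compound is needed for the effect, a lower number that less compound is needed:
- compound 1 `Nc1nc(Cl)c2ncn(C3CC(CO)C(O)C3O)c2n1`: > 100 ug/mL, a limit of the assay
- compound 2 `Nc1nc(O)c2ncn(C3CC(CO)C(O)C3O)c2n1`: > 100 ug/mL, a limit of the assay
- compound 3 `CNc1nc(N)nc2c1ncn2C1CC(CO)C(O)C1O`: 18 ug/mL

Compound 3 carries the only number shown in this assay; the other two entries sit at the limit of > 100 ug/mL in this assay, at which 2 of the 3 values shown sit. The step of an at least 5.5-fold lower number from compound 1 to compound 3 (0.74 log units; beyond the scatter) and the step of an at least 5.5-fold lower number from compound 2 to compound 3 (0.74 log units; beyond the scatter) both set methylamino apart from chloro and from hydroxy, while the step that the two limits leave unreadable from compound 1 to compound 2 cannot be read from the two limits.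

Compound 4 `CSc1nc(N)nc2c1ncn2C1CC(CO)C(O)C1O` differs from compound 3 by methylsulfanyl in place of methylamino on an aromatic carbon. Within the data shown here, no measured step swaps methylamino for methylsulfanyl, so its size has to be inferred. Methylamino is the one group at this position that gives a readable number; chloro left compound 1 at the limit and hydroxy left compound 2 at the limit. Compound 4 is therefore expected to move back toward that limit, with a step estimated as a 3.3-fold higher number from compound 3 to compound 4 (0.52 log units; beyond the scatter). The estimate for compound 4 is 60 ug/mL, with a range from 20 ug/mL to 200 ug/mL.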

Compound 4, concentration for half-maximal effect: > 100 ug/mL
Compound 4: a limit, no number; the forecaster's own chance of this, stated with the estimate: 40%; at least 1.6-fold (0.22 log units) between middle value and limit.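

In this assay, methylsulfanyl in place of methylamino on the aromatic carbon gives an at least 5.5-fold higher number from compound 3 to compound 4 (0.74 log units; beyond the scatter), so a third group at this position joins chloro and hydroxy without a readable number. Methylamino and methylsulfanyl both have 2 heavy atoms, so a group of that count at this position is not enough on its own to give a number. The steps from compound 1 and from compound 2 to compound 4 cannot be read, and the series now sits largely at one limit: the limit of > 100 ug/mL in this assay, at which 3 of the 4 values shown sit.

As far as these compounds go, it remains open whether the number of compound 3 is particular to methylamino or extends to a plain amino group, a dimethylamino group or a longer chain on the nitrogen. From the compounds shown here alone, how far compound 1, compound 2 and compound 4 lie from one another also stays unknown.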